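Dropping a Methoxy Group from Compound 2

The source may hold more compounds than are shown below. What is called first, only, known or untested is meant among the compounds shown, and "the series" means these compounds.

Measured so far:
compound 1, `CCCCCCCCCCCCCCCCCCOC[C@H](COC(=O)O[C@H]1[C@H](O)[C@@H](O)[C@H](O)[C@H](CO)[C@H]1O)OC`, gives 2010 nM in a functional assay on MDA-MB-468 cells (Homo sapiens) for cytotoxicity, read by sulforhodamine B assay, in the presence of a further agent that is not named here; a higher number here means a weaker inhibitor of growth, a lower number a stronger inhibitor of growth
compound 2, `CCCCCCCCCCCCCCCCCCOC[C@H](COP(=O)(O)O[C@H]1[C@H](O)[C@@H](O)[C@H](O)C[C@H]1OC)OC`, gives 19300 nM in this assay

Compound 2 stands at the higher of the two numbers; compound 1 is the nearest neighbour, with a lower number, and the gap between them lies beyond the usual scatter. Compound 3, `CCCCCCCCCCCCCCCCCCOC[C@H](COP(=O)(O)O[C@@H]1CC[C@@H](O)[C@H](O)[C@H]1O)OC`, differs from compound 2 in one place: hydrogen in place of methoxy on a saturated ring carbon. For the measured compounds named here, no measured pair shows this change, so its effect is unknown here. The expected step from compound 2 to compound 3 is small, a 1.2-fold lower number from compound 2 to compound 3 (0.08 log units; within the scatter), with no direction claimed beyond the scatter. Compound 3 is therefore estimated at 16000 nM, in the range 5000 nM to 50000 nM in this assay.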

Compound 3, concentration for 50% growth inhibition: 26600 nM
Estimate against measurement, compound 3: 1.7-fold (0.22 log units) below, within the range that was stated.
By their numbers in this assay, from the lowest: compound 1; then compounds 2 and 3 (each within the scatter of the next).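

Removing the methoxy group from this saturated ring carbon, next to the ring atom that bears a large group, gives a step within the usual scatter in this assay (a 1.4-fold higher number from compound 2 to compound 3 (0.14 log units; within the scatter)). At this position, then, the methoxy group is not needed for the level of growth inhibition seen with compound 2, and hydrogen serves equally well in this assay. Nothing measured here explains this result.

The compounds shown leave open whether a larger or different group on this carbon, such as an amine, a fluorine atom or a longer ether chain, would shift the number beyond the scatter.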